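A few compounds are considered here, and "the series" means these few. Any claim that something is new, unique, unknown or untested is made for them only; others in the source may bear on it.

- compound 1 `CC1(/C=C/c2ccc(C(F)(F)F)cc2)C=CC(=O)O1`: 15700 nM
- compound 2 `COc1ccccc1/C=C/C1(C)C=CC(=O)O1`: 41100 nM
- compound 3 `COc1cccc(/C=C/C2(C)C=CC(=O)O2)c1`: 37600 nM

In a functional assay on U-251 cells (Homo sapiens) for inhibition, read by sulforhodamine B assay, with a stated time of 48 h (a lower number here means a stronger inhibitor of growth, a higher number a weaker inhibitor of growth), compound 1 has the lowest number of the three, 15700 nM, and both other compounds lie beyond the scatter from it. Compound 4 `COc1ccc(/C=C/C2(C)C=CC(=O)O2)cc1` has not yet been measured. It carries methoxy in place of trifluoromethyl on an aromatic carbon.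

Among the compounds with values here, no measured pair shows this change directly. However, the two measured methoxy compounds are compound 2, at 41100 nM, and compound 3, at 37600 nM. Compound 4 is therefore expected to resemble them in this assay, as a weaker inhibitor than compound 1. The expected change, beyond the scatter, is a 2.3-fold higher number from compound 1 to compound 4 (0.36 log units; beyond the scatter). For compound 4, the estimate is 36000 nM, with an expected range of 20000 nM to 65000 nM.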

Compound 4, concentration for total growth inhibition: 127000 nM
The estimate for compound 4 lay 3.5-fold (0.55 log units) below the measured number; the whole stated range lies below it.
By their numbers in this assay, from the lowest: compound 1; then compounds 3 and 2 (each within the scatter of the next); then compound 4.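

In this assay, within the data shown here, putting methoxy in place of trifluoromethyl on this aromatic carbon gives an 8.1-fold higher number from compound 1 to compound 4 (0.91 log units; beyond the scatter), the only direct reading of this change. The position of methoxy on the ring also appears to matter: compound 4 gives 127000 nM, whereas compound 3 gives 37600 nM and compound 2 gives 41100 nM. Nothing available explains this loss of growth inhibition. Going by these compounds, it remains open how an amine, a carboxylic acid or a chlorine atom at this position would compare with trifluoromethyl and methoxy.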